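This account rests on a few compounds, and the source may have more. Where it says the series, first, only, none or still open, it means among the compounds named here.

Working notes on the series. Three members have been measured in a functional assay on PC-12 cells (Rattus norvegicus) for cytotoxicity, read by MTT assay, with stated times of 3 h and 2 h, tested at 10 uM (on this read-out lower numbers stand for a weaker effect and higher numbers for a stronger effect at the one concentration tested), so far. Compound 1 `COc1ccc(-c2cc3ccc(OCCCn4cc(CNC(=O)CCCCC5CCSS5)nn4)cc3oc2=O)cc1` gives 57.6% in this assay, compound 2 `Cc1cc(=O)oc2cc(OCCCCCn3cc(CNC(=O)CCCCC4CCSS4)nn3)ccc12` gives 66.3%, and compound 3 `CC(=O)c1cc2ccc(OCCCCCn3cc(CNC(=O)CCCCC4CCSS4)nn3)cc2oc1=O` gives 20.8%. Compound 3 thus stands lowest of the three numbers: the nearest value, that of compound 1, lies higher by a margin beyond the usual scatter, and the value of compound 2 lies higher still, also beyond the scatter. For the measured compounds named here, no pair of measured compounds differs in a single place, so no step within the measured set can be drawn.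

The next member, compound 4 `O=C(CCCCC1CCSS1)NCc1cn(CCCCCOc2ccc3cc(-c4ccccc4)c(=O)oc3c2)nn1`, is awaiting measurement in this assay. It differs from compound 3 in one place only: phenyl in place of acetyl on an aromatic carbon. With a phenyl entering in place of the acetyl, compound 4 is expected to move up from the low value of compound 3, with the step of a number 34.2 percentage points higher from compound 3 to compound 4 (beyond the scatter) estimated to exceed the scatter, because compound 1 gives 57.6% and compound 2 gives 66.3%. The estimate for compound 4 in this assay is 55%, within a range from 35% to 75%.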

Compound 4, a percentage reported as activity, at one concentration (the size of the read-out at that concentration, not a potency): 26.3%
Compound 4: the middle estimate sits 28.7 percentage points above what was measured; measured number below the stated range.
By their numbers in this assay, from the lowest: compounds 3 and 4 (each within the scatter of the next); then compounds 1 and 2 (each within the scatter of the next).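

In this assay, phenyl in place of acetyl on this aromatic carbon gives a number 5.5 percentage points higher from compound 3 to compound 4 (within the scatter). For the compounds shown here, this is the first single-place comparison, and it shows that this position carries either a six-membered aromatic ring of carbon only or acetyl, with its double bond and hydrogen-bond acceptor, without a step beyond the scatter. Nothing available bears on why these two groups read alike.

Compounds 1 and 2 differ from compound 3 and compound 4 in more than one place, so steps to them cannot be read, and what separates their values stays unassigned. Also open, from the compounds shown here alone, is whether an amine or a carboxylic acid on the same aromatic carbon would read like phenyl and acetyl.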